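Ester to acid on a thiophene aminobenzoate series

The source may report more compounds than this note shows. Statements on the series, on what has been measured and on what is new or still open speak of the compounds shown alone.

Measured compounds:
compound 1, `COC(=O)c1c(Nc2ccc(F)cc2)sc(C(=O)c2ccc(OC)cc2)c1C`, 23.3%
compound 2, `COC(=O)c1c(Nc2ccc(Cl)cc2)sc(C(=O)c2ccc(OC)cc2)c1C`, "not active" (no number reported)
compound 3, `COC(=O)c1c(Nc2ccc(C)cc2)sc(C(=O)c2ccc(C)cc2)c1C`, "not active" (no number reported)

In a functional assay, with a stated time of 150 min, tested at 30 ug/mL (a lower number here means a weaker effect, a higher number a stronger effect of the compound at the concentration tested), compound 1 gives 23.3%, the only numerical read-out of the three. Compound 2 stands without a number: in this assay compound 2 is recorded as "not active" (no number reported). The same holds for compound 3, which in this assay is also given as "not active" (no number reported). Among the measured compounds shown here, nothing more than these three entries is known, and no step between measured compounds is recorded, so no size of step can be read from the data.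

Compound 4, `COc1ccc(C(=O)c2sc(Nc3ccc(Cl)cc3)c(C(=O)O)c2C)cc1`, differs from compound 2 in one place: hydrogen in place of methyl on an oxygen next to a carbonyl group. The change reads methoxycarbonyl to carboxy. For the measured compounds named here, since compound 2 carries no number, the starting point for this step is itself uncertain, and the one numerical value of the series, that of compound 1, is modest. Any step in this assay from compound 2 to compound 4 is expected to be small, most likely within the scatter, without a direction that can be stated. Compound 4 is therefore estimated to give 10% in this assay, with a range from 0% to 30%, and it may well again be reported without a number.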

Compound 4, a percentage reported as activity, at one concentration (the size of the read-out at that concentration, not a potency): "not active" (no number reported)
For compound 4 the study gives words and no number, and the estimate cannot be compared.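

In this assay, among the compounds shown here, compound 2 and compound 4 are both recorded in words only, so no step from methoxycarbonyl to carboxy can be read between them. Nothing shown bears on this result. The compounds shown leave open whether this change alters the read-out in this assay at all.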